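Notes on carboxylic acid variants of the shared core

This account rests on a few compounds, and the source may have more. Where it says the series, first, only, none or still open, it means among the compounds named here.

Compound 1 `Cc1ccccc1-n1nc(C)c2c1NC(=O)[C@H](C)S[C@@H]2c1ccc(Oc2ccccc2C(=O)O)cc1` carries a 2-carboxyphenoxy group and is reported in an assay on isolated protein for agonist activity at Bile acid receptor (Homo sapiens), read by AlphaScreen, with a stated time of 30 min (a lower number here means that less compound is needed, a higher number that more compound is needed for the effect), as "not active" (no number reported); no single number exists for it, so its standing among the measured values cannot be placed on a scale. The two compounds with a plain phenoxy group do give numbers: compound 2 `Cc1ccc(-n2nc(C)c3c2NC(=O)[C@H](C)S[C@@H]3c2ccc(Oc3ccccc3)cc2)cc1` gives 3400 nM and compound 3 `CCCc1ccccc1-n1nc(C)c2c1NC(=O)[C@H](C)S[C@@H]2c1ccc(Oc2ccccc2)cc1` gives 1100 nM, with a 3.1-fold lower number from compound 2 to compound 3 (0.49 log units; beyond the scatter).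

Compound 4 `Cc1ccccc1-n1nc(C)c2c1NC(=O)[C@H](C)S[C@@H]2c1ccc(-c2ccc(C(=O)O)cc2)cc1` differs from compound 1 in one place: 4-carboxyphenyl in place of 2-carboxyphenoxy on an aromatic carbon. Going by the values given here, the only measured step concerns the group on the aromatic nitrogen, a different place, so it does not bear directly on the change from compound 1 to compound 4; it shows only that the series as a whole sits in the micromolar region and that changes at the periphery move the number by a modest amount. Whether the change from compound 1 to compound 4 moves the number beyond the scatter cannot be judged from these data, and the direction is open.

With compound 1 reported as "not active" (no number reported) and compounds 2 and 3 in the low micromolar range, compound 4 is estimated at 1000 nM, with a wide range from 150 nM to 8000 nM.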

Compound 4, half-maximal effective concentration: "not active" (no number reported)
Compound 4: no number reported; no gap can be computed for the estimate.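

In this assay compound 1 ("not active" (no number reported)) and compound 4 ("not active" (no number reported)) carry no number, so no new step can be read between them. The compounds shown leave open whether any carboxylic acid variant of the shared core gives a measurable number at all. No supporting data on hand bear on this result.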